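This account rests on a few compounds, and the source may have more. Where it says the series, first, only, none or still open, it means among the compounds named here.

Measured in a functional assay on LNCaP cells (Homo sapiens) for antiproliferative activity, read by propidium iodide staining, with a stated time of 96 h; on this read-out lower numbers stand for stronger inhibition and higher numbers for weaker inhibition:
- compound 1 `CC(O)(CSc1cccc(S(F)(F)(F)(F)F)c1)C(=O)Nc1ccc(C#N)c(C(F)(F)F)c1`: 14500 nM
- compound 2 `CC(O)(CSc1ccc(S(F)(F)(F)(F)F)cc1)C(=O)Nc1cccc(S(F)(F)(F)(F)F)c1`: 12700 nM
- compound 3 `CC(O)(CSc1ccc(F)cc1)C(=O)Nc1cccc(S(F)(F)(F)(F)F)c1`: 26900 nM

In this assay, compound 3 sits within the scatter of compound 1, and its number is higher than that of compound 2 by a gap beyond the scatter. Compound 4 `CC(O)(CSc1cccc(C(F)(F)F)c1)C(=O)Nc1cccc(S(F)(F)(F)(F)F)c1` differs from compound 3 on a sulfur: 3-(trifluoromethyl)phenyl in place of 4-fluorophenyl on a sulfur. Within the data shown here, only one measured step changes the group on that sulfur, a 2.1-fold higher number from compound 2 to compound 3 (0.33 log units; beyond the scatter), and it is modest. On that single step, no change beyond the scatter is expected in this assay, with at most a slight drift to a lower number. The expected step is a 1.5-fold lower number from compound 3 to compound 4 (0.17 log units; within the scatter). For compound 4 the estimated value is 18000 nM, with an expected range of 8000 nM to 40000 nM.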

Compound 4, half-maximal inhibitory concentration: 12700 nM
Estimate against measurement, compound 4: 1.4-fold (0.15 log units) above; the measured number falls inside the stated range.
By their numbers in this assay, from the lowest: compounds 2, 4, 1 and 3 (each within the scatter of the next, the first and the last beyond it).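

In this assay a second replacement of the 4-fluorophenyl on the sulfur also gives a lower number, a 2.1-fold lower number from compound 3 to compound 4 (0.33 log units; beyond the scatter), so compound 3 now lies beyond the scatter of both neighbours that differ from it only in this group. Compound 2 at 12700 nM and compound 4 at 12700 nM print the same value, so two different groups on the sulfur land on one number. No measurement on hand accounts for this step.

From the compounds shown here alone, whether a cyclohexyl group or a simple methyl on the sulfur would hold that number remains open. So does the effect of a carboxylic acid or an amine on the aromatic ring.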